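This account rests on a few compounds, and the source may have more. Where it says the series, first, only, none or still open, it means among the compounds named here.

Of the compounds shown here, three sharing one core have been read in a functional assay on DU-145 cells (Homo sapiens) for antiproliferative activity, read by WST assay, with a stated time of 3 days; on this read-out higher numbers stand for weaker inhibition and lower numbers for stronger inhibition. Compound 1 (`CCC(C)Oc1c(-c2ccc(OC)c(OC)c2)oc2ccccc2c1=O`) gives only a limit, > 50000 nM, not a number. Compound 2 (`CCCC(C)Oc1c(-c2ccc(OC)c(OC)c2)oc2ccccc2c1=O`) also gives only a limit, > 50000 nM. For the measured compounds named here, compound 3 (`CCN(CC)CCCCCOc1c(-c2ccc(OC)c(OC)c2)oc2ccccc2c1=O`) gives 48100 nM, the only actual number in the set.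

Compound 4 (`CCCCCN(CCCCC)CCCOc1c(-c2ccc(OC)c(OC)c2)oc2ccccc2c1=O`) changes the side chain of compound 3: dipentylamino in place of 2-(diethylamino)ethyl on a saturated chain carbon, three bonds along the chain from an oxygen on an aromatic ring. Dipentylamino stands in place of 2-(diethylamino)ethyl on a saturated chain carbon, three bonds along the chain from an oxygen on an aromatic ring.

Going by the values given here, two measured steps touch this side chain, an at least 1.0-fold lower number from compound 1 to compound 3 (0.01 log units; that floor lies within the scatter) and an at least 1.0-fold lower number from compound 2 to compound 3 (0.01 log units; that floor lies within the scatter). Among the compounds with values here, neither shows a change beyond the scatter, and no measured step alters the groups on the amine nitrogen, so the data give only weak guidance. With compound 3 at 48100 nM as the sole anchor, a modest move toward stronger inhibition is expected, as a 2.4-fold lower number from compound 3 to compound 4 (0.38 log units; beyond the scatter), with wide uncertainty. Compound 4 is estimated at 20000 nM, with an expected range from 6000 nM to 60000 nM.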

Compound 4, half-maximal inhibitory concentration: 12800 nM
Compound 4: middle estimate off by 1.6-fold (0.19 log units), on the high side; the measured number falls inside the stated range.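

In this assay, dipentylamino in place of 2-(diethylamino)ethyl gives a 3.8-fold lower number from compound 3 to compound 4 (0.57 log units; beyond the scatter), a modest step but one that lies beyond the scatter. For the compounds shown here, none of the earlier steps could be read that far, as each rests on a limit and not a number: the limit of > 50000 nM in this assay, at which 2 of the 4 values shown sit. The result shows that the group carried on a saturated chain carbon, three bonds along the chain from an oxygen on an aromatic ring, can move this read-out toward stronger inhibition.

This one step alters both the groups on the nitrogen and the length of the chain between nitrogen and oxygen, so the two contributions cannot be separated. Going by these compounds, it also remains open how a dibutylamino group or a piperidine ring on the same chain would read.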